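The compounds below may be only part of what the source reports. "The series", "measured", "known", "first", "only" and "open" are said of these compounds alone.

Measured so far in an ADME assay on HEL cells (Homo sapiens) for cytotoxicity; a lower number here means that less compound is tolerated, a higher number that more compound is tolerated:
compound 1 `O=C(COc1cccc2ccccc12)N/N=C/c1ccc(O)cc1`: 20 ug/mL
compound 2 `C/C(=N\NC(=O)COc1cccc2ccccc12)c1ccccc1Br`: 20 ug/mL
compound 3 `O=C(COc1cccc2ccccc12)N/N=C/c1ccc([N+](=O)[O-])cc1`: 20 ug/mL

In this assay compound 1 gives 20 ug/mL, and compounds 2 and 3 sit level with it at the digits shown. Going by the values given here, the only single-point step in the set, no change at the digits printed from compound 1 to compound 3 (within the scatter), nitro in place of hydroxy on an aromatic carbon, stays within the scatter.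

Compound 4 `O=C(COc1cccc2ccccc12)N/N=C/c1cccc(Br)c1` differs from compound 1 by 3-bromophenyl in place of 4-hydroxyphenyl on a carbon with a double bond to nitrogen. Among the compounds with values here, no measured step covers this exchange; the one step available, no change at the digits printed from compound 1 to compound 3 (within the scatter), replaces the same hydroxy group and is flat, and compound 2, which also carries a bromine, shows the same value as compound 1. The expectation is therefore no step beyond the scatter, no change at the digits printed from compound 1 to compound 4 (within the scatter). Compound 4 is estimated at 20 ug/mL, with a range of 10 ug/mL to 40 ug/mL.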

Compound 4, minimum cytotoxic concentration: 100 ug/mL
The estimate for compound 4 lay 5.0-fold (0.70 log units) below the measured number; measured number outside the range, above it.
By their numbers in this assay, from the lowest: compounds 1, 2 and 3 (each within the scatter of the next); then compound 4.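

In this assay, going by these compounds alone, the group on the carbon with a double bond to nitrogen does matter: 3-bromophenyl in place of 4-hydroxyphenyl gives a 5.0-fold higher number from compound 1 to compound 4 (0.70 log units; beyond the scatter) and is the first step in the set beyond the scatter. Replacing the hydroxy group alone did not show this, as the nitro exchange gave no change at the digits printed from compound 1 to compound 3 (within the scatter). Compound 4 differs from compound 1 in both the substituent and its place on the ring, so the step cannot be assigned to either alone.

Still open, from the compounds shown here alone, is how an amine or a carboxylic acid on this phenyl ring would read. Nothing at hand explains the step.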